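This account rests on a few compounds, and the source may have more. Where it says the series, first, only, none or still open, it means among the compounds named here.

Two compounds here share a core and differ only at the side that carries the methoxy groups. For compound 1, `COc1cc(-c2cc(/C=C/C(=O)c3ccc(Cl)c(Cl)c3)[nH]n2)cc(OC)c1OC`, the result in a functional assay on DU-145 cells (Homo sapiens) for inhibition, read by sulforhodamine B assay, with a stated time of 48 h (a higher number here means a weaker inhibitor of growth, a lower number a stronger inhibitor of growth), is "not determined" (no result reported). Among the compounds with values here, compound 2, `COc1ccc(C(=O)/C=C/c2cc(-c3cc(OC)c(OC)c(OC)c3)n[nH]2)cc1OC`, was measured, and in this assay compound 2 gives 550 nM; as the only number recorded, it is the sole point of reference. Compound 3, `COc1ccc(C(=O)/C=C/c2cc(-c3cc(OC)c(OC)c(OC)c3)n[nH]2)cc1`, differs from compound 2 in one place: hydrogen in place of methoxy on an aromatic carbon, ortho to a methoxy group and meta to a large group, so that 3,4-dimethoxyphenyl becomes 4-methoxyphenyl. Within the data shown here, no pair of measured compounds shows what such a change does here, so the expectation rests on the single value of compound 2 alone. One methoxy group leaves and a hydrogen enters, and a shift of modest size toward weaker inhibition of growth is expected, with the step of a 1.6-fold higher number from compound 2 to compound 3 (0.21 log units; within the scatter) estimated to lie close to the usual scatter. Compound 3 is therefore expected to give about 900 nM in this assay, within a range from 300 nM to 3000 nM.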

Compound 3, concentration for 50% growth inhibition: 1430 nM
The estimate for compound 3 lay 1.6-fold (0.20 log units) below the measured number, and the stated range covers the measured number.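

Compound 2 alone could only give a starting number, but the pair now gives this position its first reading: in this assay, going from 3,4-dimethoxyphenyl to 4-methoxyphenyl produces a 2.6-fold higher number from compound 2 to compound 3 (0.41 log units; beyond the scatter). The step is modest, yet it lies beyond the usual scatter, so this methoxy group, ortho to a methoxy group and meta to a large group, is not a silent passenger, and replacing it with hydrogen weakens growth inhibition in this pair. This is one pair and one change, so it shows a direction at this single position and no general rule, and nothing measured here explains why the number rises.

Going by these compounds, what remains open is whether hydrogen is a special case, since a hydroxy group, a fluorine atom, an amine or a longer chain such as ethoxy in the place of this methoxy could each move the number differently. The step that would compare the methoxy-bearing ring with the ring carrying two chlorine atoms cannot be read, as compound 1 offers no number to set beside the others.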